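This account rests on a few compounds, and the source may have more. Where it says the series, first, only, none or still open, it means among the compounds named here.

So far, two compounds have been tested in a functional assay, with a stated time of 10 min; on this read-out lower numbers stand for stronger inhibition and higher numbers for weaker inhibition. Compound 1 `O=c1cc(/C=C/c2ccccc2O)[nH]cc1O` gives 2210 nM, while compound 2 `O=c1cc(/C=C/c2cc(O)cc(O)c2)[nH]cc1O` gives 880 nM. Compound 2 therefore has the lower number of the two and is the stronger inhibitor, by a gap beyond the usual scatter of repeated measurements. The next compound, compound 3 `Cn1cc(O)c(=O)cc1/C=C/c1cc(O)cc(O)c1`, is compound 2 with one change: methyl in place of hydrogen on an aromatic nitrogen. Within the data shown here, no pair of measured compounds shows what this change does in this assay, so any forecast here is uncertain. A small shift toward weaker inhibition is expected, with no move beyond the scatter. The estimated step is a 1.3-fold higher number from compound 2 to compound 3 (0.10 log units; within the scatter). For compound 3 the estimated value is 1100 nM, with an expected range of 350 nM to 3500 nM.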

Compound 3, half-maximal inhibitory concentration: 1190 nM
Estimate against measurement, compound 3: 1.1-fold (0.03 log units) below; measured number inside the range.
By their numbers in this assay, from the lowest: compounds 2, 3 and 1 (each within the scatter of the next, the first and the last beyond it).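

Until now, nothing showed what the aromatic nitrogen of the shared core contributes in this assay. Methyl in place of hydrogen at this position gives a 1.4-fold higher number from compound 2 to compound 3 (0.13 log units; within the scatter), so this pair offers no sign that the hydrogen on this nitrogen matters for inhibition. Among these compounds, the single step cannot say why the two compounds read alike, and no other measurement here bears on that question.

Going by these compounds, a methyl is only a small group, so it remains open whether a longer chain such as propyl, or a chain ending in an amine or a carboxylic acid, would be accepted on this nitrogen. On these data alone, it is also open whether the same methyl change would give a similar step on compound 1, which has a different hydroxy pattern.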